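This account rests on a few compounds, and the source may have more. Where it says the series, first, only, none or still open, it means among the compounds named here.

Working notes on the series. In an assay for inhibition of 6-phosphofructo-2-kinase/fructose-2,6-bisphosphatase 3 (Homo sapiens), read by ADP-Glo, with a stated time of 2 h (on this read-out higher numbers stand for weaker inhibition and lower numbers for stronger inhibition), compound 1 `CN1CCC(CNS(=O)(=O)c2ccccc2Nc2cc(-c3ccc4ccn(C)c4c3)c3nccnc3c2)C1` gives 11 nM, compound 2 `Cn1ccc2ccc(-c3cc(Nc4ccccc4S(N)(=O)=O)cc4nccnc34)cc21` gives 265 nM, and compound 3 `Cn1ccc2ccc(-c3cc(Nc4cnccc4C(=O)NCc4cncnc4)cc4nccnc34)cc21` gives 106 nM. Compound 3 thus stands second highest of the three numbers, with compound 2 higher and compound 1 lower, both gaps beyond the scatter. For the measured compounds named here, the only single-point step measured so far is a 24-fold higher number from compound 1 to compound 2 (1.38 log units; beyond the scatter), which concerns the sulfonamide nitrogen and not the amide side chain. Compound 4 `Cn1cc(CNC(=O)c2ccncc2Nc2cc(-c3ccc4ccn(C)c4c3)c3nccnc3c2)cn1` differs from compound 3 by 1-methyl-1H-pyrazol-4-yl in place of pyrimidin-5-yl on a saturated chain carbon bound to an amide-type nitrogen. Going by the values given here, no measured step bears on this exchange, so in this assay no shift beyond the scatter is expected, giving a 1.1-fold lower number from compound 3 to compound 4 (0.03 log units; within the scatter). Compound 4 is therefore estimated at 100 nM, within 40 nM to 250 nM.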

Compound 4, half-maximal inhibitory concentration: 159 nM
For compound 4 the middle estimate is 1.6-fold (0.20 log units) below the measured one; low and high end bracket the measured number.
By their numbers in this assay, from the lowest: compound 1; then compounds 3, 4 and 2 (each within the scatter of the next, the first and the last beyond it).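

In this assay, 1-methyl-1H-pyrazol-4-yl in place of pyrimidin-5-yl on a saturated chain carbon bound to an amide-type nitrogen gives a 1.5-fold higher number from compound 3 to compound 4 (0.18 log units; within the scatter). At this place, then, a five-membered aromatic ring stands in for a six-membered one, with equal counts of heavy atoms and hetero atoms, without a shift beyond the scatter. Nothing available accounts for this result.

Open, as far as these compounds go, is whether any group other than these two aromatic rings holds the number at this place. A phenyl ring, a carboxylic acid or a longer chain would test that.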